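A few compounds are considered here, and "the series" means these few. Any claim that something is new, unique, unknown or untested is made for them only; others in the source may bear on it.

Within the data shown here, compound 2 `COc1cc2cc(Oc3ccc(NC(=O)Nc4ccc(Cl)c(C(F)(F)F)c4)cc3)c(C)nc2cc1OC` gives 831 nM in a functional assay on SR cells (Homo sapiens) for inhibition, read by sulforhodamine B assay, with a stated time of 48 h (a lower number here means a stronger inhibitor of growth, a higher number a weaker inhibitor of growth), the lowest of the two numbers so far; its nearest neighbour, compound 1 `COc1cc2cc(Oc3ccc(NC(=O)Nc4cccc(C(F)(F)F)c4)cc3)c(C)nc2cc1OC`, gives 1170 nM, and the step of a 1.4-fold lower number from compound 1 to compound 2 (0.15 log units; within the scatter) stays within the scatter. Compound 3 `COc1cc2cc(Oc3ccc(NC(=O)Nc4ccc(Cl)c(Cl)c4)cc3)c(C)nc2cc1OC` differs from compound 2 by chloro in place of trifluoromethyl on an aromatic carbon. Among the measured compounds shown here, no measured step swaps trifluoromethyl for chloro; the only measured step, from compound 1 to compound 2, adds a chloro and is within the scatter, so it offers little guidance. Compound 3 is therefore expected to sit near compound 2, with an estimated step of a 1.6-fold higher number from compound 2 to compound 3 (0.19 log units; within the scatter). The estimate for compound 3 is 1300 nM, with a range from 500 nM to 3500 nM.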

Compound 3, concentration for 50% growth inhibition: 3100 nM
Compound 3: middle estimate off by 2.4-fold (0.38 log units), on the low side, and the stated range covers the measured number.
By their numbers in this assay, from the lowest: compounds 2 and 1 (each within the scatter of the next); then compound 3.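

In this assay, among these compounds, chloro in place of trifluoromethyl is the first change to move the number beyond the scatter, with a 3.7-fold higher number from compound 2 to compound 3 (0.57 log units; beyond the scatter), so this position responds to which group it carries, and trifluoromethyl gives the lower number here. The 3,4-dichlorophenyl group also reads weaker than the 3-(trifluoromethyl)phenyl group, with a 2.6-fold higher number from compound 1 to compound 3 (0.42 log units; beyond the scatter). No measurement bearing on the reason for this difference is available. The compounds shown leave open whether another group at this place, such as a nitrile, methoxy or an amine, would match trifluoromethyl or go lower.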